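Inverting one ring stereocentre in the adenine-bearing compound

The source may hold more compounds than are shown below. What is called first, only, known or untested is meant among the compounds shown, and "the series" means these compounds.

In a functional assay on CCRF-HSB-2 cells (Homo sapiens) for antiproliferative activity (a higher number here means a weaker inhibitor, a lower number a stronger inhibitor), compound 1 `CCc1cn([C@H]2S[C@H](CO)[C@@H](O)[C@@H]2O)c(=O)[nH]c1=O` gives > 100 ug/mL, which is a limit of the assay and not a number. Compound 2 `Nc1ncnc2c1ncn2[C@H]1S[C@H](CO)[C@@H](O)[C@@H]1O` gives > 100 ug/mL, again a limit and not a number. As far as these compounds go, compound 2 therefore stands at the limit of > 100 ug/mL in this assay, at which 2 of the 2 values shown sit, and its true position remains unknown. Going by the values given here, no measured step is available to size a structural change.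

Compound 3 `Nc1ncnc2c1ncn2[C@@H]1S[C@H](CO)[C@@H](O)[C@@H]1O` is the next compound to consider: the two compounds have the same atoms and bonds and differ only in configuration as drawn: 1 of 4 stereo elements differ; a stereocentre at a saturated ring carbon is drawn S in compound 2 and R in compound 3. A single inverted stereocentre could leave activity out of reach or could reveal it, so any expectation here is loose. The expected at least 2.5-fold lower number from compound 2 to compound 3 (0.39 log units; beyond the scatter) points toward stronger inhibition, but its size is poorly constrained. For compound 3 the estimated value in this assay is 40 ug/mL, with an expected range of 4 ug/mL to 100 ug/mL.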

Compound 3, half-maximal inhibitory concentration: 14.8 ug/mL
For compound 3 the middle estimate is 2.7-fold (0.43 log units) above the measured one; the range from low to high includes it.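

Going by these compounds alone, compound 3 is the first compound with a number rather than a limit in this assay, so the configuration at one saturated ring carbon is enough to bring the adenine-bearing compound within the measurable range: the fact that compounds 2 and 3 differ only in the configuration as drawn. Compound 2 gives > 100 ug/mL, which is a limit of the assay and not a number. As far as these compounds go, the inversion therefore gives an at least 6.7-fold lower number from compound 2 to compound 3 (0.82 log units; beyond the scatter), a bound on the step, and its true size stays unknown.

Whether the same inversion would bring compound 1 within the measurable range remains open, as the compounds shown include no matching pair for it. Also open, from the compounds shown here alone, is whether a methoxy group or a fluorine in place of a hydroxyl group would preserve the activity seen with compound 3.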